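Moving the chlorine on the aryl ring of compound 2

The source may hold more compounds than are shown below. What is called first, only, known or untested is meant among the compounds shown, and "the series" means these compounds.

Measured so far:
- compound 1, `OC(CCn1nc2c(Br)c(Br)c(Br)c(Br)c2n1)c1ccc(F)cc1`, 116%
- compound 2, `OC(CCn1nc2c(Br)c(Br)c(Br)c(Br)c2n1)c1cccc(Cl)c1`, 97%
- compound 3, `C[C@H](O)CCn1nc2c(Br)c(Br)c(Br)c(Br)c2n1`, 112%

All three share a core and differ only in the group on the saturated chain carbon bound to an oxygen on a saturated carbon and a saturated chain carbon. In a functional assay on MCF7 cells (Homo sapiens) for antiproliferative activity, read by MTT assay, with a stated time of 24 h, tested at 12.5 uM (a lower number here means a stronger effect, a higher number a weaker effect of the compound at the concentration tested), compound 2 gives 97%, the lowest of the three numbers; compound 3 is nearer to it, compound 1 further away, and both gaps lie beyond the scatter.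

Compound 4, `OC(CCn1nc2c(Br)c(Br)c(Br)c(Br)c2n1)c1ccc(Cl)cc1`, is not yet measured. 4-chlorophenyl in place of 3-chlorophenyl on a saturated chain carbon bound to an oxygen on a saturated carbon and a saturated chain carbon The same atoms are present, joined differently.

Among the compounds with values here, only one measured step concerns a change of the aryl group at this place: a number 19 percentage points lower from compound 1 to compound 2 (beyond the scatter). Within the data shown here, no step shows what moving a chlorine on the ring does. Because 116% for compound 1 and 112% for compound 3 both lie above compound 2, a small rise is expected, so a number 7 percentage points higher from compound 2 to compound 4 (within the scatter) is estimated. Compound 4 is therefore expected to give about 104%, within 90% to 120%.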

Compound 4, a percentage reported as activity, at one concentration (the size of the read-out at that concentration, not a potency): 90%
The estimate for compound 4 lay 14 percentage points above the measured number, within the range that was stated.
By their numbers in this assay, from the lowest: compounds 4 and 2 (each within the scatter of the next); then compounds 3 and 1 (each within the scatter of the next).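

In this assay, moving the chlorine gives a number 7 percentage points lower from compound 2 to compound 4 (within the scatter), so the 3-chlorophenyl and 4-chlorophenyl groups cannot be told apart here. The step from compound 1 to compound 2 changed both the halogen and its place on the ring, whereas a number 26 percentage points lower from compound 1 to compound 4 (beyond the scatter) changes only the halogen, chloro in place of fluoro on an aromatic carbon, and this step is the one that lies beyond the scatter. No measurement at hand explains why the halogen counts for more than its place in these compounds.

As far as these compounds go, whether a bromine or an amine in place of the chlorine of compound 4 would take the number further down remains open. These read-outs also come from a single concentration, so they say nothing about potency.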